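A 5-nitrothiophen-2-yl swap on the carbonyl carbon

This account rests on a few compounds, and the source may have more. Where it says the series, first, only, none or still open, it means among the compounds named here.

In an ADME assay on HepG2 cells (Homo sapiens) for cytotoxicity (a lower number here means that less compound is tolerated, a higher number that more compound is tolerated), compound 1 (`O=C(N[C@H](/C=C/S(=O)(=O)c1ccccc1)CCc1ccccc1)c1cccc2cccnc12`) gives > 80000 nM as a limit of the assay. Among the measured compounds shown here, compound 2 (`Cn1cc([N+](=O)[O-])nc1C(=O)N[C@H](/C=C/S(=O)(=O)c1ccccc1)CCc1ccccc1`) gives 28800 nM as the only actual number so far. Compound 3 (`O=C(N[C@H](/C=C/S(=O)(=O)c1ccccc1)CCc1ccccc1)c1ccc([N+](=O)[O-])s1`) differs from compound 2 in one group on a carbonyl carbon (5-nitrothiophen-2-yl in place of 1-methyl-4-nitro-1H-imidazol-2-yl on a carbonyl carbon). For the measured compounds named here, at that place the one measured step (an at least 2.7-fold lower number from compound 1 to compound 2 (0.44 log units; beyond the scatter)) replaced a different group, so it guides the size only loosely. No step beyond the scatter is expected in this assay for this swap, and the expected change (a 1.2-fold lower number from compound 2 to compound 3 (0.08 log units; within the scatter)) is small. Compound 3 is estimated at 24000 nM with a range from 9000 nM to 70000 nM on this read-out.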

Compound 3, half-maximal cytotoxic concentration: 12400 nM
Compound 3: middle estimate off by 1.9-fold (0.29 log units), on the high side; the range from low to high includes it.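

In this assay, the position on the carbonyl carbon proves sensitive even between two nitro-bearing five-membered aromatic rings: 5-nitrothiophen-2-yl in place of 1-methyl-4-nitro-1H-imidazol-2-yl gives a 2.3-fold lower number from compound 2 to compound 3 (0.37 log units; beyond the scatter). Against quinolin-8-yl, the same group gives an at least 6.4-fold lower number from compound 1 to compound 3 (0.80 log units; beyond the scatter). Compound 1 remains a limit of the assay, so this step is a bound and not a measured size: the limit of > 80000 nM in this assay, at which 1 of the 3 values shown sits. The compounds shown leave open whether the nitro group itself is tied to the lower numbers, as a nitrile or a carboxylic acid in its place could show.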